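The source may hold more compounds than are shown below. What is called first, only, known or untested is meant among the compounds shown, and "the series" means these compounds.

Three compounds have been measured in an ADME assay on BJ cells (Homo sapiens) for cytotoxicity, with a stated time of 72 h (a lower number here means that less compound is needed, a higher number that more compound is needed for the effect), and give these readings:

- Compound 1 `COc1cccc(-c2nc3c(c(C)nn3-c3ccccc3)c(-c3ccccc3O)c2C#N)c1` gives > 23000 nM (a limit of the assay, not a number)
- Compound 2 `Cc1ccc(-c2nc3c(c(C)nn3-c3ccccc3)c(-c3ccccc3O)c2C#N)cc1` gives 22200 nM
- Compound 3 `CCCc1ccc(-c2nc3c(c(C)nn3-c3ccccc3)c(-c3ccccc3O)c2C#N)cc1` gives 22500 nM

Compound 3 stands level with compound 2 on these numbers, as the measured change is a 1.0-fold higher number from compound 2 to compound 3 (0.01 log units; within the scatter). Against the limit of compound 1, the two steps are floors only: an at least 1.0-fold lower number from compound 1 to compound 2 (0.01 log units; that floor lies within the scatter) and an at least 1.0-fold lower number from compound 1 to compound 3 (0.00 log units; that floor lies within the scatter). All three compounds therefore sit close together in this assay.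

Compound 4 `Cc1nn(-c2ccccc2)c2nc(-c3ccc(Cl)cc3)c(C#N)c(-c3ccccc3O)c12` has chloro in place of propyl on an aromatic carbon. Among the compounds with values here, no measured compound carries chloro, so the closest guide is the change in that same group, where lengthening the methyl of compound 2 to the propyl of compound 3 gave a 1.0-fold higher number from compound 2 to compound 3 (0.01 log units; within the scatter). No step beyond the scatter is expected, and a reading reported only as a limit is also possible.

The expected result is a 1.2-fold lower number from compound 3 to compound 4 (0.07 log units; within the scatter).

For compound 4 the estimate is 19000 nM, with an expected range of 10000 nM to 26000 nM.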

Compound 4, half-maximal effective concentration: > 20000 nM
Compound 4: only a limit was reported; the forecaster's own chance of this, stated with the estimate: 30%; middle value at least 1.0-fold (0.02 log units) away from the limit.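

In this assay compound 4 gives > 20000 nM, a limit of the assay and not a number, so no step can be read from compound 1, compound 2 or compound 3 to compound 4. The compounds shown leave open whether chloro in place of propyl changes the reading at all.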